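The compounds below may be only part of what the source reports. "The series", "measured", "known", "first", "only" and "open" are said of these compounds alone.

Measured in a functional assay on SMMC-7721 cells (Homo sapiens) for cytotoxicity, read by MTT assay, with a stated time of 24 h; a lower number here means a stronger inhibitor, a higher number a weaker inhibitor:
- compound 1 `O=C1/C(=C/c2cccnc2)CN(S(=O)(=O)c2ccc(C(F)(F)F)cc2)C/C1=C\c1ccccc1F`: 7900 nM
- compound 2 `O=C1/C(=C/c2cccnc2)CN(S(=O)(=O)c2ccc(Br)cc2)C/C1=C\c1ccccc1F`: 9100 nM
- compound 3 `N#Cc1ccc(S(=O)(=O)N2C/C(=C\c3cccnc3)C(=O)/C(=C/c3ccccc3F)C2)cc1`: 15400 nM

Compound 1 cannot be separated from its two neighbours in this assay. The data show a 1.2-fold higher number from compound 1 to compound 2 (0.06 log units; within the scatter) and a 1.9-fold higher number from compound 1 to compound 3 (0.29 log units; within the scatter), while the remaining pair shows a 1.7-fold higher number from compound 2 to compound 3 (0.23 log units; within the scatter). All three compounds therefore stand together.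

Compound 4 `O=C1/C(=C/c2ccncc2)CN(S(=O)(=O)c2ccc(C(F)(F)F)cc2)C/C1=C\c1ccccc1F` is related to compound 1 by one change: pyridin-4-yl in place of pyridin-3-yl on a double-bonded chain carbon bound to a double-bonded ring carbon. That is, pyridin-4-yl stands in place of pyridin-3-yl on a double-bonded chain carbon bound to a double-bonded ring carbon.

Going by the values given here, none of the measured steps touches this place. Each exchanges trifluoromethyl, bromo or cyano on an aromatic carbon, so they bear on the new change only indirectly. They show a series that has stayed flat so far, but they say nothing about the pyridine nitrogen's position.

With no evidence for a direction, no shift beyond the scatter is expected, and the reading of compound 1 at 7900 nM serves as the anchor. The expected step is a 1.1-fold higher number from compound 1 to compound 4 (0.06 log units; within the scatter), which is no real change.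

For compound 4 the estimated value is 9000 nM, with an expected range of 4500 nM to 18000 nM.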

Compound 4, half-maximal inhibitory concentration: 11100 nM
Beside the measured number, compound 4's estimate is 1.2-fold (0.09 log units) below it; the range from low to high includes it.
By their numbers in this assay, from the lowest: compounds 1, 2, 4 and 3 (each within the scatter of the next).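

In this assay, the exchange of pyridin-3-yl for pyridin-4-yl gives a 1.4-fold higher number from compound 1 to compound 4 (0.15 log units; within the scatter), so the two groups cannot be told apart at this place. The earlier steps shown here all exchanged groups on an aromatic carbon, whereas this one reaches a different part of the molecule: a double-bonded chain carbon bound to a double-bonded ring carbon. It extends the flat picture to this place, but only for one exchange between two groups with the same atoms, and it shows no preference between them.

The compounds shown leave open whether a pyridin-2-yl group, a plain phenyl ring, or a pyridine ring carrying an amine or a carboxylic acid would stay within the scatter of compound 1 at this place. Nothing at hand explains the flat reading at this position.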